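This account rests on a few compounds, and the source may have more. Where it says the series, first, only, none or still open, it means among the compounds named here.

Measured so far:
compound 1, `CC(C)c1cccc(C(C)C)c1NC(=O)NC1=NN(Cc2ccccc2)NN1`: 370 nM
compound 2, `CCCCCCCCCN1NN=C(NC(=O)Nc2c(C(C)C)cccc2C(C)C)N1`: 31 nM

In an assay on microsomes from intestine for inhibition of acyl-CoA:cholesterol acyltransferase (Oryctolagus cuniculus) (on this read-out lower numbers stand for stronger inhibition and higher numbers for weaker inhibition), compound 2 gives 31 nM, the lower of the two numbers, while compound 1 gives 370 nM, a gap beyond the usual scatter. Compound 3, `COC(=O)CCCCCCCCCCN1NN=C(NC(=O)Nc2c(C(C)C)cccc2C(C)C)N1`, differs from compound 2 by (methoxycarbonyl)methyl in place of hydrogen on a saturated chain carbon, nine bonds along the chain from an amine nitrogen in a ring. For the measured compounds named here, no measured pair shows a change of this kind, so the expectation rests on compound 2 alone. The step of a 1.9-fold higher number from compound 2 to compound 3 (0.29 log units; within the scatter) is expected to be small, a slight rise that may not exceed the scatter. Compound 3 is estimated at 60 nM, within 15 nM to 250 nM.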

Compound 3, half-maximal inhibitory concentration: 4700 nM
Compound 3: the middle estimate sits 78-fold (1.89 log units) below what was measured; the measured number lies above the stated range.
By their numbers in this assay, from the lowest: compound 2; then compound 1; then compound 3.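

In this assay the change to (methoxycarbonyl)methyl in place of hydrogen on a saturated chain carbon, nine bonds along the chain from an amine nitrogen in a ring, gives a 150-fold higher number from compound 2 to compound 3 (2.18 log units; beyond the scatter) and so shows that this far end of the chain is not indifferent to what is added. Compound 1 and compound 2 could not show this. No measurement here explains the loss of inhibition. Still open, from the compounds shown here alone, is whether the added length or the methoxycarbonyl end matters more, which a longer chain, a carboxylic acid or an amine at this place could help separate.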